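Cytotoxicity of a nitrobenzofurazan anilide: a dimethoxyphenyl variant

The source may hold more compounds than are shown below. What is called first, only, known or untested is meant among the compounds shown, and "the series" means these compounds.

Compound 1 `O=C(CCC(=O)OCCCCCCSc1ccc([N+](=O)[O-])c2nonc12)Nc1ccccc1F` has been measured in an ADME assay on L02 cells (Homo sapiens) for cytotoxicity, read by MTT assay, with a stated time of 72 h (on this read-out higher numbers stand for weaker inhibition and lower numbers for stronger inhibition), where compound 1 gives 4270 nM. Compound 2 `O=C(CCC(=O)OCCCCCCSc1ccc([N+](=O)[O-])c2nonc12)Nc1ccccc1Cl` differs from it only by chloro in place of fluoro on an aromatic carbon, and in this assay compound 2 gives 5850 nM; the step of a 1.4-fold higher number from compound 1 to compound 2 (0.14 log units; within the scatter) is within the scatter. Compound 1 thus stands with the lowest of the two numbers shown, but its gap to compound 2 is within the scatter and supports no order between them. Compound 3 `COc1ccc(NC(=O)CCC(=O)OCCCCCCSc2ccc([N+](=O)[O-])c3nonc23)cc1OC` is not yet measured. It differs from compound 1 on an amide-type nitrogen: 3,4-dimethoxyphenyl in place of 2-fluorophenyl on an amide-type nitrogen. Among the measured compounds shown here, the only measured step, chloro in place of fluoro on an aromatic carbon, was small, and no measured pair covers 3,4-dimethoxyphenyl in place of 2-fluorophenyl, so there is no ground for expecting a step beyond the scatter. The estimated step is a 1.1-fold higher number from compound 1 to compound 3 (0.02 log units; within the scatter). Compound 3 is therefore expected to give about 4500 nM in this assay, within a range from 1800 nM to 11000 nM.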

Compound 3, half-maximal inhibitory concentration: 4100 nM
For compound 3 the middle estimate is 1.1-fold (0.04 log units) above the measured one; the measured number falls inside the stated range.
By their numbers in this assay, from the lowest: compounds 3, 1 and 2 (each within the scatter of the next).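

In this assay, 3,4-dimethoxyphenyl in place of 2-fluorophenyl on the amide-type nitrogen gives a 1.0-fold lower number from compound 1 to compound 3 (0.02 log units; within the scatter) and, in place of 2-chlorophenyl, gives a 1.4-fold lower number from compound 2 to compound 3 (0.15 log units; within the scatter) on this read-out. The earlier pair had covered only chloro in place of fluoro on an aromatic carbon, whereas these steps replace the whole substituent, with the halogen leaving and hydrogen-bond acceptors entering, and still no separation from the scatter appears. No supporting evidence bears on why these numbers stay together.

As far as these compounds go, all three compounds carry a six-membered aromatic ring of carbon only at this nitrogen, so it remains open whether an aminophenyl or carboxyphenyl group, or an open-chain alkyl group, would also stay within the scatter. The compounds shown also vary nothing else, leaving open what a longer chain in the linker would do.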